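This account rests on a few compounds, and the source may have more. Where it says the series, first, only, none or still open, it means among the compounds named here.

Measured compounds in the series:

compound 1 `CNC(=O)c1cncc(NS(=O)(=O)c2cc(Cl)ccc2OC)c1` — 109 nM
compound 2 `COc1ccc(Br)cc1S(=O)(=O)Nc1cncc(C(N)=O)c1` — 14 nM

Both were tested in an assay on isolated protein for inhibition of alkaline phosphatase, tissue-nonspecific isozyme (Homo sapiens); a higher number here means a weaker inhibitor, a lower number a stronger inhibitor. Compound 1 gives 109 nM and stands highest of the two numbers; the nearest is compound 2 with 14 nM, a gap that lies beyond the usual scatter. The two differ in more than one place, so their gap is read only as what the two values show.

Compound 3 `COC(=O)c1cncc(NS(=O)(=O)c2cc(Cl)ccc2OC)c1` is not yet measured. It differs from compound 1 by methoxy in place of methylamino on a carbonyl carbon. Said in the same words, a methylamino group leaves and a methoxy group enters on the carbonyl carbon that is attached to the aromatic carbon of the shared core, so a methylcarbamoyl becomes a methoxycarbonyl.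

Within the data shown here, no measured pair shows this change, so the size of the step is open. The expectation is a modest step toward a higher number, at the edge of the scatter, from compound 1 to compound 3 of a 2.0-fold higher number from compound 1 to compound 3 (0.30 log units; within the scatter). Compound 3 is accordingly estimated at 220 nM, with a range of 60 nM to 800 nM.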

Compound 3, half-maximal inhibitory concentration: 65 nM
For compound 3 the middle estimate is 3.4-fold (0.53 log units) above the measured one; the range from low to high includes it.
By their numbers in this assay, from the lowest: compound 2; then compounds 3 and 1 (each within the scatter of the next).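

On the carbonyl carbon attached to the aromatic carbon of the shared core, methoxy in place of methylamino gives in this assay a 1.7-fold lower number from compound 1 to compound 3 (0.22 log units; within the scatter), so this pair cannot be told apart in this read-out. Among these compounds, a hydrogen-bond donor leaves with the methylamino group and a hydrogen-bond acceptor enters with the methoxy group, and this exchange still leaves the number within the scatter, which the earlier compounds, differing in more than one place, could not show. Nothing measured bears on why the two compounds sit this close.

From the compounds shown here alone, one exchange on this carbonyl carbon does not show how far the position tolerates change, and a plain amino group, a hydroxyl group as in the carboxylic acid, or an ethoxy group or longer alkoxy chain there on the core of compound 1 remain open. Going by these compounds, whether a methoxycarbonyl behaves the same way with a bromine in place of the chlorine on the other ring also remains open.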